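A Benzyl Swap on Sulfur at the Solubility Limit

This account rests on a few compounds, and the source may have more. Where it says the series, first, only, none or still open, it means among the compounds named here.

Measured in a physicochemical assay for solubility; on this read-out lower numbers stand for lower solubility and higher numbers for higher solubility:
Compound 1 `O=C(O)c1ccc(C(=O)/C(=C\c2ccc(F)c([N+](=O)[O-])c2)Sc2ccc(Br)cc2)cc1`: < 1000 ug/mL
Compound 2 `O=C(O)c1ccc(C(=O)/C(=C\c2ccc(F)cc2[N+](=O)[O-])SCc2ccc(Br)cc2)cc1`: < 1000 ug/mL
Compound 3 `O=C(O)c1ccc(C(=O)/C(=C\c2ccc(Br)c([N+](=O)[O-])c2)SCc2ccc(F)cc2)cc1`: < 1000 ug/mL

Compound 1 has no exact number, only the limit < 1000 ug/mL. The whole set stands the same way, with the limit of < 1000 ug/mL in this assay, at which 3 of the 3 values shown sit. Compound 4 `Cc1ccc(CS/C(=C/c2ccc(F)c([N+](=O)[O-])c2)C(=O)c2ccc(C(=O)O)cc2)cc1` differs from compound 1 by having 4-methylbenzyl in place of 4-bromophenyl on a sulfur. Within the data shown here, no measured pair shows this change in this assay, so no direction can be argued and no step beyond the scatter is expected. The expectation rests on compound 1 at its limit of < 1000 ug/mL. The estimated change is a step that the limit leaves unreadable from compound 1 to compound 4. Another limit is the likeliest report. For compound 4 the expected value is 700 ug/mL, with an estimated range from 250 ug/mL to 1000 ug/mL.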

Compound 4, solubility: < 1000 ug/mL
Compound 4: a limit, no number; the forecaster's own chance of this, stated with the estimate: 90%; the middle value does not contradict the limit.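

No step can be read from compound 1 to compound 4 in this assay, because each gives only a limit and not a number: the limit of < 1000 ug/mL in this assay, at which 4 of the 4 values shown sit.
Going by these compounds, whether 4-methylbenzyl in place of 4-bromophenyl on a sulfur changes the result at all stays open.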